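Changing the aryl group on an inactive compound

This account rests on a few compounds, and the source may have more. Where it says the series, first, only, none or still open, it means among the compounds named here.

In a functional assay on U-87MG ATCC cells for inhibition, with U-87 MG (Homo sapiens) as the target, read by MTT assay, with a stated time of 72 h (on this read-out higher numbers stand for weaker inhibition and lower numbers for stronger inhibition), compound 1 (`Cc1ccnc(NC(c2ccc(C(F)(F)F)cc2)c2ccc3cccnc3c2O)c1`) gives 2100 nM as its half-maximal inhibitory concentration. Compound 2 (`Cc1ccnc(NC(c2ccccc2C)c2ccc3cccnc3c2O)c1`) gives > 10000 nM which is a limit and not a number: the only mark of its place is the limit of > 10000 nM in this assay, at which 1 of the 2 values shown sits, and no exact reading exists.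

The change to compound 3 (`Cc1ccnc(NC(c2cccc(F)c2)c2ccc3cccnc3c2O)c1`), still unmeasured, is 3-fluorophenyl in place of 2-methylphenyl on a saturated chain carbon bound to an aromatic carbon and a nitrogen on an aromatic ring at a saturated chain carbon bound to an aromatic carbon and a nitrogen on an aromatic ring. Within the data shown here, the one measured step at this place is an at least 4.7-fold higher number from compound 1 to compound 2 (0.67 log units; beyond the scatter) with 2-methylphenyl replacing 4-(trifluoromethyl)phenyl, and it lies beyond the scatter. That step shows that the group here can shift the number, so leaving 2-methylphenyl may lower it again. In this assay the expected result is an at least 2.0-fold lower number from compound 2 to compound 3 (0.30 log units; that floor lies within the scatter) toward stronger inhibition, though its size stays uncertain. Compound 3 is estimated at 5000 nM with an expected range from 1800 nM to 14000 nM around it.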

Compound 3, half-maximal inhibitory concentration: 9200 nM
For compound 3 the middle estimate is 1.8-fold (0.26 log units) below the measured one, within the range that was stated.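

In this assay, moving from 2-methylphenyl to 3-fluorophenyl gives an at least 1.0-fold lower number from compound 2 to compound 3 (0.03 log units; that floor lies within the scatter), so this change cannot be shown to lower the number at all. The size of that step stays unknown because compound 2 is held only by a limit, not a number: the limit of > 10000 nM in this assay, at which 1 of the 3 values shown sits. Against the other reference, the result is firmer: a 4.4-fold higher number from compound 1 to compound 3 (0.64 log units; beyond the scatter), so 3-fluorophenyl does not bring back the level seen with 4-(trifluoromethyl)phenyl, and among these three aryl groups only that one gives a number clearly lower than the other two.

On these data alone, what remains open is whether the lower number depends on the trifluoromethyl group itself or would also appear with another group on the phenyl ring, such as a nitrile or a methoxy group. A cyclohexyl group in place of the phenyl ring is equally untested by these compounds.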